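Chloro in Place of Methyl: An Expectation for Compound 4

The source may hold more compounds than are shown below. What is called first, only, known or untested is meant among the compounds shown, and "the series" means these compounds.

Going by the values given here, compound 3 `CCN(CC)CCCOc1cc2ncnc(Nc3nc4ccc(C(=O)Nc5c(C)cccc5C)cc4s3)c2cc1OC` gives the highest of the three known numbers in a functional assay on K562 cells (Homo sapiens) for cytotoxicity, read by WST assay, with a stated time of 72 h (on this read-out lower numbers stand for stronger inhibition and higher numbers for weaker inhibition), at 28400 nM. Compound 2 `COc1cc2c(Nc3nc4ccc(C(=O)Nc5c(C)cccc5C)cc4s3)ncnc2cc1OCCCN1CCCC1` gives 15700 nM, and the step of a 1.8-fold higher number from compound 2 to compound 3 (0.26 log units; within the scatter) stays within the scatter. Compound 1 `COc1cc2c(Nc3nc4ccc(C(=O)Nc5c(C)cccc5Cl)cc4s3)ncnc2cc1OCCCN1CCCCC1C` gives 6800 nM, a lower number than compound 3, but those two differ in two places, so no single step can be read from that pair. Compound 4 `CCN(CC)CCCOc1cc2ncnc(Nc3nc4ccc(C(=O)Nc5c(C)cccc5Cl)cc4s3)c2cc1OC` differs from compound 3 by one change: chloro in place of methyl on an aromatic carbon. Among the compounds with values here, no measured step isolates this change; compound 1 carries the same chloro group beside a different amine, and its value set against that of compound 2 hints at a lower number. The expected step of a 2.4-fold lower number from compound 3 to compound 4 (0.37 log units; beyond the scatter) is therefore modest and downward, and compound 4 is estimated at 12000 nM, within 5000 nM to 28000 nM.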

Compound 4, half-maximal inhibitory concentration: 9600 nM
For compound 4 the middle estimate is 1.3-fold (0.10 log units) above the measured one; low and high end bracket the measured number.
By their numbers in this assay, from the lowest: compounds 1, 4, 2 and 3 (each within the scatter of the next, the first and the last beyond it).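

In this assay, chloro in place of methyl now has a measured step of its own, with the diethylamino chain held the same (a 3.0-fold lower number from compound 3 to compound 4 (0.47 log units; beyond the scatter)). With the 2-chloro-6-methylphenyl group kept, diethylamino in place of 2-methylpiperidin-1-yl gives a step that stays within the scatter (a 1.4-fold higher number from compound 1 to compound 4 (0.15 log units; within the scatter)). No measurement at hand accounts for either step.

The compounds shown leave open whether the chloro step would repeat with the pyrrolidin-1-yl chain of compound 2. They also leave open how fluoro or bromo would compare on that same aromatic carbon.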